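Carbamate on the ring amine: from compound 2 to compound 4

A few compounds are considered here, and "the series" means these few. Any claim that something is new, unique, unknown or untested is made for them only; others in the source may bear on it.

Values in a functional assay on PC-3 cells (Homo sapiens) for inhibition, read by MTT assay, with a stated time of 72 h (a higher number here means a weaker inhibitor, a lower number a stronger inhibitor), for the measured members of the series:
Compound 1 `COc1cc(Cn2cc(CSC(=S)N3CCN(C(=O)OCc4ccccc4)CC3)nn2)cc(OC)c1OC` — > 128000 nM
Compound 2 `COc1cc(Cn2cc(CSC(=S)N3CCNCC3)nn2)cc(OC)c1OC` — > 128000 nM
Compound 3 `CC(C)(C)OC(=O)N1CCN(C(=S)SCc2cn(Cc3ccccc3Cl)nn2)CC1` — 12500 nM

Compound 2 stands at a limit of this assay, not at a number. Compound 1 likewise sits at a limit, which is the limit of > 128000 nM in this assay, at which 2 of the 3 values shown sit. Going by the values given here, the only step measured between neighbours that differ in one place is a step that the two limits leave unreadable from compound 1 to compound 2, and with both ends at a limit its size cannot be read. Among the compounds with values here, compound 3 is the one member with a number; it carries the tert-butoxycarbonyl group but differs from compound 2 in the group on the triazole nitrogen as well, so no single step joins it to compound 2, and its value shows only that a tert-butoxycarbonyl-bearing member can give a reading inside the range of this assay.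

Compound 4 `COc1cc(Cn2cc(CSC(=S)N3CCN(C(=O)OC(C)(C)C)CC3)nn2)cc(OC)c1OC` is not yet measured. Its change from compound 2 is tert-butoxycarbonyl in place of hydrogen on an amine nitrogen in a ring. Within the data shown here, no readable step speaks to this change, since the one related step, from compound 1 to compound 2, is unreadable. No step beyond the scatter is therefore expected in this assay; a value at or near the limit is expected for compound 4, with the number tied to compound 3 marking the stronger end of what seems plausible.

Compound 4 is estimated at 100000 nM, in a range from 20000 nM to 300000 nM, which means an expected step of an at least 1.2-fold lower number from compound 2 to compound 4 (0.10 log units; that floor lies within the scatter).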

Compound 4, half-maximal inhibitory concentration: > 128000 nM
Compound 4: only a limit was reported; the forecaster's own chance of this, stated with the estimate: 60%; middle value at least 1.2-fold (0.10 log units) away from the limit.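

In this assay compound 4 gives > 128000 nM, which is a limit and not a number. No step from compound 1 or compound 2 to compound 4 can be read, since all three sit at the same limit: the limit of > 128000 nM in this assay, at which 3 of the 4 values shown sit.

Still open, from the compounds shown here alone, is whether any group on the ring amine nitrogen of this core gives a number in this assay.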